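The source may hold more compounds than are shown below. What is called first, only, known or untested is meant among the compounds shown, and "the series" means these compounds.

Of the compounds shown here, three that share one core have been measured in an assay for displacement of a labelled ligand from adenosine receptor A1 (Rattus norvegicus); on this read-out higher numbers stand for weaker inhibition and lower numbers for stronger inhibition. Compound 2, `CCCCC(Sc1nc(N)c2cnn(-c3ccccc3)c2n1)C(N)=O`, gives 0.939 nM, the lowest of the three numbers. Compound 1, `CCCC(Sc1nc(SC)c2cnn(-c3ccccc3)c2n1)C(N)=O`, gives 7.55 nM, and compound 3, `CCCCC(Sc1nc(S)c2cnn(-c3ccccc3)c2n1)C(N)=O`, gives 37.2 nM. For the measured compounds named here, the only single-point step, a 40-fold higher number from compound 2 to compound 3 (1.60 log units; beyond the scatter), concerns a group on an aromatic carbon rather than the chain. Compound 4, `CCC(Sc1nc(N)c2cnn(-c3ccccc3)c2n1)C(N)=O`, differs from compound 2 only in the chain: hydrogen in place of ethyl on a saturated chain carbon, three bonds along the chain from a carbonyl carbon and a sulfur. Going by the values given here, no measured step changes the chain alone, and compound 1 and compound 2 differ in two places at once, so their values cannot separate the chain from the group on the aromatic carbon. Compound 4 is therefore expected to shift only modestly, by a 2.1-fold higher number from compound 2 to compound 4 (0.33 log units; beyond the scatter). Compound 4 is estimated at 2 nM, within a range from 0.6 nM to 8 nM.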

Compound 4, inhibition constant: 1.56 nM
Compound 4: the middle estimate sits 1.3-fold (0.11 log units) above what was measured, within the range that was stated.
By their numbers in this assay, from the lowest: compounds 2 and 4 (each within the scatter of the next); then compound 1; then compound 3.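

In this assay, replacing ethyl with hydrogen on this saturated chain carbon, which shortens butyl to ethyl, gives a 1.7-fold higher number from compound 2 to compound 4 (0.22 log units; within the scatter), so the two chain lengths cannot be told apart. For the compounds shown here, this is the first step that changes the chain alone, and it is far smaller than a 40-fold higher number from compound 2 to compound 3 (1.60 log units; beyond the scatter), the step at the aromatic carbon. No evidence is available to explain this result. On these data alone, whether the same holds for a longer chain such as hexyl, or for a phenyl group at this place, remains open.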